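The compounds below may be only part of what the source reports. "The series", "measured", "known", "first", "only" and "open" are said of these compounds alone.

Measured so far in a functional assay on MCF7 cells (Homo sapiens) for cytotoxicity, read by MTT assay, with a stated time of 72 h, tested at 100 uM; a lower number here means less inhibition of growth, a higher number more inhibition of growth at the concentration tested:

- compound 1 `Cc1cccc(/C(N)=N/NC(=S)N2CCN(c3ccccn3)CC2)n1`: 49.8%
- compound 2 `N/C(=N\NC(=S)N1CCCC1)c1ccc(F)cn1`: 73%
- compound 3 `Cc1cccc(/C(N)=N/NC(=S)N2CCCC2)n1`: 61.8%

Compound 2 stands highest of the three numbers in this assay. Its nearest neighbour is compound 3, whose value lies lower by a margin beyond the usual scatter; compound 1 lies lower still, also beyond the scatter. No two of the measured compounds differ in only one place, so none of the gaps between them can be read as a single-change step.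

Compound 4 `N/C(=N\NC(=S)N1CCOCC1)c1ccc(F)cn1` is the next compound to be run in this assay. Relative to compound 2 the change is morpholin-4-yl in place of pyrrolidin-1-yl on a thiocarbonyl carbon. For the measured compounds named here, nothing among the measured compounds shows what this exchange does, so the size of the step is open. The working expectation is a modest move, more likely downward than upward, with a real chance that the step stays within the scatter. The expected step from compound 2 onward is a number 11 percentage points lower from compound 2 to compound 4 (beyond the scatter). Compound 4 is accordingly estimated at 62% in this assay, with a range from 42% to 80%.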

Compound 4, percent growth inhibition at one concentration: 61.5%
Compound 4: the middle estimate sits 0.5 percentage points above what was measured, and the stated range covers the measured number.
By their numbers in this assay, from the lowest: compound 1; then compounds 4 and 3 (each within the scatter of the next); then compound 2.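

For the compounds shown here, with the rest of compound 2 held fixed, morpholin-4-yl in place of pyrrolidin-1-yl on a thiocarbonyl carbon gives the first single-change step in this assay (a number 11.5 percentage points lower from compound 2 to compound 4 (beyond the scatter)). The group on this carbon therefore affects the read-out, and this exchange of a five-membered ring for a six-membered ring carrying an oxygen lowers the number by more than the scatter, although compound 4 still gives 61.5% at the concentration tested. No measurement shown explains the step or separates the contributions of the ring size and the oxygen.

The compounds shown leave open whether the step goes with the larger ring or with the ring oxygen; piperidin-1-yl, a six-membered ring without that oxygen, on the same thiocarbonyl carbon would separate the two. Also open, going by these compounds, is whether the exchange has a step of similar size on the core of compound 3, which would take morpholin-4-yl in place of its pyrrolidin-1-yl.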